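This account rests on a few compounds, and the source may have more. Where it says the series, first, only, none or still open, it means among the compounds named here.

Compound 3 `CC/N=C(\S)NCCCn1nc(-c2ccccc2)ccc1=O` stands at a limit in a functional assay on the whole organism (stomach) with Rattus norvegicus as the target (on this read-out lower numbers stand for an effect already at smaller amounts and higher numbers for an effect only at larger amounts of compound), giving > 100 mg/kg. Compound 1 `CC/N=C(/NC#N)NCCCn1nc(-c2ccccc2)ccc1=O` gives 78.3 mg/kg in this assay. Compound 2 `CCC/N=C(/NC#N)NCCCCn1nc(-c2ccccc2)ccc1=O` gives > 100 mg/kg, again a limit. For the measured compounds named here, the step of an at least 1.2-fold higher number from compound 1 to compound 3 (0.10 log units; that floor lies within the scatter) is the only measured step that touches compound 3, and its floor follows from the limit of > 100 mg/kg in this assay, at which 2 of the 3 values shown sit. Compound 4 `C/N=C(\S)NCCCCn1nc(-c2ccccc2)ccc1=O` differs from compound 3 by a group of 6 heavy atoms (3 carbon, 2 nitrogen, 1 sulfur; no ring) in place of a group of 6 heavy atoms (3 carbon, 2 nitrogen, 1 sulfur; no ring), on a saturated chain carbon, three bonds along the chain from an aromatic nitrogen. Going by the values given here, no measured step covers this rearrangement; the pair of compound 1 and compound 2 shows only a number set against a limit. With compound 3 itself at a limit, compound 4 is expected to stay near that floor, with a step that the limit leaves unreadable from compound 3 to compound 4 in no clear direction. The estimate for compound 4 is 150 mg/kg, in a range from 60 mg/kg to 400 mg/kg.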

Compound 4, dose for half-maximal effect: 28.9 mg/kg
Estimate against measurement, compound 4: 5.2-fold (0.72 log units) above; the measured number lies below the stated range.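

On a saturated chain carbon, three bonds along the chain from an aromatic nitrogen, the same atoms joined differently give a readable change in this assay: an at least 3.4-fold lower number from compound 3 to compound 4 (0.53 log units; beyond the scatter). Against the nitrile-bearing compounds, a 2.7-fold lower number from compound 1 to compound 4 (0.43 log units; beyond the scatter) is the first step between two true numbers that lies beyond the scatter, and an at least 3.4-fold lower number from compound 2 to compound 4 (0.53 log units; beyond the scatter). The steps from compound 2 and compound 3 are floors that rest on a limit: the limit of > 100 mg/kg in this assay, at which 2 of the 4 values shown sit.

The compounds shown do not separate the effect of the chain from that of the group on the amine nitrogen. From the compounds shown here alone, how a longer chain or a carboxylic acid at this place would read also remains open.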